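This account rests on a few compounds, and the source may have more. Where it says the series, first, only, none or still open, it means among the compounds named here.

Compound 1 `COc1ccc([C@@H]2CC(=O)c3c(O)cc(OCc4cn(Cc5cccc(Cl)c5)nn4)cc3O2)cc1O` gives 18200 nM in a functional assay on RAW264.7 cells (Mus musculus) for inhibition, read by Griess assay, with stated times of 2 h and 24 h; on this read-out higher numbers stand for weaker inhibition and lower numbers for stronger inhibition. It stands at the highest of the three numbers shown, though its steps to the other two stay within the scatter: compound 2 `COc1ccc([C@@H]2CC(=O)c3c(O)cc(OCc4cn(Cc5cccc(C)c5)nn4)cc3O2)cc1O` gives 17400 nM in this assay, and compound 3 `CCCCn1cc(COc2cc(O)c3c(c2)O[C@H](c2ccc(OC)c(O)c2)CC3=O)nn1` gives 13900 nM in this assay. The step of a 1.0-fold lower number from compound 1 to compound 2 (0.02 log units; within the scatter) and the step of a 1.3-fold lower number from compound 1 to compound 3 (0.12 log units; within the scatter) both lie within the scatter, as does a 1.3-fold lower number from compound 2 to compound 3 (0.10 log units; within the scatter).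

Compound 4 `COc1ccc([C@@H]2CC(=O)c3c(O)cc(OCc4cn(Cc5cccc(C(F)(F)F)c5)nn4)cc3O2)cc1O` differs from compound 1 by trifluoromethyl in place of chloro on an aromatic carbon. The step that bears most directly on this change is a 1.0-fold lower number from compound 1 to compound 2 (0.02 log units; within the scatter), where another group replaced the chloro on the same aromatic carbon and the number hardly moved; exchanging the whole 3-chlorophenyl for propyl in a 1.3-fold lower number from compound 1 to compound 3 (0.12 log units; within the scatter) shifted it only slightly. The step of a 1.1-fold lower number from compound 1 to compound 4 (0.03 log units; within the scatter) is therefore expected to stay within the scatter, with no clear direction. For compound 4 in this assay the estimate is 17000 nM, within a range from 8500 nM to 34000 nM.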

Compound 4, half-maximal inhibitory concentration: 19900 nM
Beside the measured number, compound 4's estimate is 1.2-fold (0.07 log units) below it; the measured number falls inside the stated range.
By their numbers in this assay, from the lowest: compounds 3, 2, 1 and 4 (each within the scatter of the next).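

In this assay, trifluoromethyl in place of chloro gives a 1.1-fold higher number from compound 1 to compound 4 (0.04 log units; within the scatter) and trifluoromethyl in place of methyl gives a 1.1-fold higher number from compound 2 to compound 4 (0.06 log units; within the scatter) on the same aromatic carbon, so a third group at this position stays within the scatter of the other two. The exchange of propyl for 3-(trifluoromethyl)phenyl gives a 1.4-fold higher number from compound 3 to compound 4 (0.16 log units; within the scatter) and also stays within the scatter, so neither change separates any of the four compounds. No measurement at hand accounts for this flat result.

The compounds shown leave open whether an amine or a carboxylic acid on this aromatic carbon would move the number beyond the scatter. They also leave open whether a longer chain in place of propyl, or a change on the shared core, would do so.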